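From 3-methylphenyl to 2-fluorophenyl on an amide-type nitrogen

This account rests on a few compounds, and the source may have more. Where it says the series, first, only, none or still open, it means among the compounds named here.

In an ADME assay on HaCaT cells (Homo sapiens) for inhibition (on this read-out higher numbers stand for weaker inhibition and lower numbers for stronger inhibition), compound 1 `COc1cc(-c2cc(C(=O)O)c3ccccc3n2)ccc1OCC(=O)Nc1ccccc1C` gives 230000 nM and compound 2 `COc1cc(-c2cc(C(=O)O)c3ccccc3n2)ccc1OCC(=O)Nc1cccc(C)c1` gives 225000 nM, so compound 2 stands level with compound 1, within the scatter. Compound 3 `COc1cc(-c2cc(C(=O)O)c3ccccc3n2)ccc1OCC(=O)Nc1ccccc1F` has 2-fluorophenyl in place of 3-methylphenyl on an amide-type nitrogen. Within the data shown here, the one measured step bearing on this swap of the aryl group is a 1.0-fold lower number from compound 1 to compound 2 (0.01 log units; within the scatter), which stays within the scatter. Among the measured compounds shown here, no measured compound carries the fluorine, so this evidence is thin, and no shift beyond the scatter is expected. The estimated change is a 1.0-fold lower number from compound 2 to compound 3 (0.01 log units; within the scatter). Compound 3 is expected at 220000 nM, with an estimated range of 120000 nM to 380000 nM.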

Compound 3, half-maximal inhibitory concentration: 161000 nM
The estimate for compound 3 lay 1.4-fold (0.14 log units) above the measured number, and the stated range covers the measured number.
By their numbers in this assay, from the lowest: compounds 3, 2 and 1 (each within the scatter of the next).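

In this assay the aryl group on the amide-type nitrogen now also carries fluorine: 2-fluorophenyl in place of 3-methylphenyl gives a 1.4-fold lower number from compound 2 to compound 3 (0.15 log units; within the scatter) and fluoro in place of methyl on an aromatic carbon gives a 1.4-fold lower number from compound 1 to compound 3 (0.15 log units; within the scatter) at the same time. Thus, for these three compounds, exchanging methyl for fluoro leaves the read-out within the scatter. Nothing measured here speaks to the reason for this.

The compounds shown leave open whether an amine or a carboxylic acid on this phenyl group would move the number beyond the scatter. They also leave open how a longer chain in place of the phenyl group would read.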